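Benzoyl ring hydroxy: expected shift from compound 2

This account rests on a few compounds, and the source may have more. Where it says the series, first, only, none or still open, it means among the compounds named here.

Measured compounds:
compound 1, `COc1cccc(C(=O)N(C)/N=C/c2ccc(OC)c(OC)c2)c1` — 69%
compound 2, `COc1ccc(/C=N/N(C)C(=O)c2ccccc2)cc1OC` — 51%

In a functional assay on the whole organism (strain A/J) for inhibition, with Mus musculus as the target, with stated times of 1 h and 18 h, at a dose of 100 umol/kg by the oral route (a higher number here means more inhibition at the dose given (going by the name of the read-out), a lower number less inhibition), compound 1 gives 69% and compound 2 gives 51%. Compound 2 stands lowest of the two numbers; its nearest neighbour is compound 1, and the measured step of a number 18 percentage points lower from compound 1 to compound 2 (beyond the scatter) came with hydrogen in place of methoxy on an aromatic carbon, a change on the benzoyl ring.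

Compound 3, `COc1ccc(/C=N/N(C)C(=O)c2ccc(O)cc2)cc1OC`, is not yet measured in this assay. Relative to compound 2 the change is hydroxy in place of hydrogen on an aromatic carbon, which reads phenyl to 4-hydroxyphenyl. Among the compounds with values here, the only measured step on this ring is a number 18 percentage points lower from compound 1 to compound 2 (beyond the scatter): taking an oxygen substituent off the benzoyl ring cost a modest amount. Putting an oxygen substituent back, now as hydroxy rather than methoxy, could recover part of that, but the two groups are not the same, so the expected step in this assay is small and upward, with a range wide enough to include no change beyond the scatter.

The step expected here is a number 7 percentage points higher from compound 2 to compound 3 (within the scatter). Compound 3 is expected to give 58%, with an estimated range from 40% to 75%.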

Compound 3, a percentage reported as inhibition, in the whole organism at one dose (the size of the read-out at that dose, not a potency): 61%
Beside the measured number, compound 3's estimate is 3 percentage points below it, within the range that was stated.
By their numbers in this assay, from the lowest: compounds 2, 3 and 1 (each within the scatter of the next, the first and the last beyond it).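

In this assay, putting hydroxy in place of hydrogen on the aromatic carbon para to a large group gives a number 10 percentage points higher from compound 2 to compound 3 (within the scatter), so a hydroxy at this place shows no shift beyond the scatter, in either direction, from the unsubstituted phenyl. Against the earlier methoxy compound, the reading is a number 8 percentage points lower from compound 1 to compound 3 (within the scatter), so 4-hydroxyphenyl and 3-methoxyphenyl cannot be told apart in this read-out, and compound 3 sits within the scatter of both neighbours even though those two neighbours stand apart beyond it. Nothing on hand bears on why the readings fall as they do.

The compounds shown leave open whether the gap between the methoxy compound and the unsubstituted phenyl follows the group or its place on the ring, since 3-methoxyphenyl and 4-hydroxyphenyl differ in both; 4-methoxyphenyl and 3-hydroxyphenyl would separate the two. Also open, going by these compounds, is how this place on the benzoyl ring responds to groups of another kind, such as an amine or a carboxylic acid, whose readings could fall outside the present narrow spread.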